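A Methyl Where a Methoxy Gave a Limit

The compounds below may be only part of what the source reports. "The series", "measured", "known", "first", "only" and "open" are said of these compounds alone.

Going by the values given here, compound 1 `COc1ccc(/C=C/c2cc(OC)cc(OC)c2/C=C/C(=O)c2cc3ccccc3oc2=O)cc1` is the only compound of this pair that returns a number in an assay on isolated protein for inhibition of Amine oxidase [flavin-containing] A (Homo sapiens), read by fluorescence, with a stated time of 15 min; a higher number here means a weaker inhibitor, a lower number a stronger inhibitor: compound 1 gives 41700 nM. Compound 2 `COc1ccc(/C=C/c2cc(OC)cc(OC)c2/C=C/C(=O)c2cc3ccc(OC)cc3oc2=O)cc1` returns in this assay only a limit of the assay, > 60000 nM, which is a limit and not a number. Among the compounds with values here, the change from compound 1 to compound 2 is methoxy in place of hydrogen on an aromatic carbon, and it gives an at least 1.4-fold higher number from compound 1 to compound 2 (0.15 log units; that floor lies within the scatter); the one piece of evidence on this step is the limit of > 60000 nM in this assay, at which 1 of the 2 values shown sits.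

Compound 3 `COc1ccc(/C=C/c2cc(OC)cc(OC)c2/C=C/C(=O)c2cc3ccc(C)cc3oc2=O)cc1` differs from compound 1 at the same place: methyl in place of hydrogen on an aromatic carbon. Within the data shown here, the only measured step that bears on this change is the one from compound 1 to compound 2, whose floor lies within the scatter while its true size may be larger. The methyl is therefore expected to move the number upward, if at all, and compound 3 may well return only a limit. Compound 3 is estimated at 60000 nM, with a range from 25000 nM to 150000 nM. This estimate for compound 3 means an expected step of a 1.4-fold higher number from compound 1 to compound 3 (0.16 log units; within the scatter).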

Compound 3, half-maximal inhibitory concentration: 58200 nM
Compound 3: the middle estimate sits 1.0-fold (0.01 log units) above what was measured; the measured number falls inside the stated range.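

Methyl in place of hydrogen on an aromatic carbon gives a 1.4-fold higher number from compound 1 to compound 3 (0.14 log units; within the scatter), so this position now carries a substituent that returns a number rather than a limit, yet that number cannot be told apart from the one without the substituent. Methyl in place of methoxy on an aromatic carbon gives an at least 1.0-fold lower number from compound 2 to compound 3 (0.01 log units; that floor lies within the scatter), which fixes no order between the two groups. Compound 2 stands only at a limit of the assay, which is not a number, and so the true size of the methoxy step stays unresolved: the limit of > 60000 nM in this assay, at which 1 of the 3 values shown sits.

Whether any group at this position can move the number beyond the scatter in this assay remains open, since only hydrogen, methyl and methoxy appear there among the compounds shown. An amine, a carboxylic acid, a chlorine atom or a longer chain such as propyl at this place would bear on that question, and whether the same holds elsewhere on the shared core is also left open.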